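The compounds below may be only part of what the source reports. "The series", "measured", "known", "first", "only" and "open" are said of these compounds alone.

Among the measured compounds shown here, compound 3 `CCN(CC)C(=O)Cc1c(-c2ccc(OCc3cccc(F)c3)cc2)nn2c(C)cc(C)nc12` is one of three compounds measured in an assay on isolated protein (kidney, strain Wistar) for displacement of a labelled ligand from Translocator protein (Rattus norvegicus), read by scintillation counting, with a stated time of 90 min; on this read-out higher numbers stand for weaker inhibition and lower numbers for stronger inhibition; in this assay compound 3 gives 0.47 nM. Its closest neighbour is compound 2 `CCN(CC)C(=O)Cc1c(-c2ccc(OCc3ccccc3F)cc2)nn2c(C)cc(C)nc12`, which in this assay gives 0.31 nM, and the step of a 1.5-fold higher number from compound 2 to compound 3 (0.18 log units; within the scatter) shows that the two cannot be told apart. Compound 1 `CCN(CC)C(=O)Cc1c(-c2ccc(OCC3CC3)cc2)nn2c(C)cc(C)nc12` gives 3 nM, and the step of a 6.4-fold lower number from compound 1 to compound 3 (0.81 log units; beyond the scatter) sets compound 3 well apart from it. The step of a 9.7-fold lower number from compound 1 to compound 2 (0.99 log units; beyond the scatter) is of the same kind.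

Compound 4 `CCN(CC)C(=O)Cc1c(-c2ccc(OCc3ccc(F)cc3)cc2)nn2c(C)cc(C)nc12` differs from compound 3 only in where the fluorine sits on the benzyl group: 4-fluorophenyl in place of 3-fluorophenyl on a saturated chain carbon bound to an oxygen on an aromatic ring. For the measured compounds named here, the one measured step that bears directly on this is the move of the fluorine from one ring position to another, a 1.5-fold higher number from compound 2 to compound 3 (0.18 log units; within the scatter), which stayed within the scatter. The larger steps from compound 1 concern the exchange of a cyclopropyl for a fluorophenyl and do not speak to shifting the fluorine around the ring.

On that basis the step of a 1.2-fold lower number from compound 3 to compound 4 (0.07 log units; within the scatter) is expected to stay within the scatter. Compound 4 is therefore estimated at 0.4 nM, with a range from 0.15 nM to 1.2 nM.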

Compound 4, inhibition constant: 0.77 nM
Beside the measured number, compound 4's estimate is 1.9-fold (0.28 log units) below it, and the stated range covers the measured number.
By their numbers in this assay, from the lowest: compounds 2, 3 and 4 (each within the scatter of the next, the first and the last beyond it); then compound 1.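

In this assay, among the compounds shown here, moving the fluorine from the 3-fluorophenyl to the 4-fluorophenyl gives a 1.6-fold higher number from compound 3 to compound 4 (0.21 log units; within the scatter) and so does not separate the two compounds, while the change from 2-fluorophenyl to 4-fluorophenyl gives a 2.5-fold higher number from compound 2 to compound 4 (0.40 log units; beyond the scatter) and is the first shift of fluorine around this ring to clear the scatter, though only modestly. The exchange of cyclopropyl for a fluorophenyl also stays beyond the scatter with the 4-fluorophenyl group, as a 3.9-fold lower number from compound 1 to compound 4 (0.59 log units; beyond the scatter) shows, so this gain holds for all three fluorine placements shown. Nothing at hand explains why these numbers differ or why the fluorine shift matters only between the 2-fluorophenyl and 4-fluorophenyl compounds.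

The compounds shown do not include a plain benzyl group without fluorine, so how much the fluorine itself adds to the fluorophenyl compounds remains open. Also open, as far as these compounds go, is whether the small effect of ring placement would hold for a different group on the same ring, such as a chlorine, a methoxy, a nitrile, an amine or a carboxylic acid.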